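This account rests on a few compounds, and the source may have more. Where it says the series, first, only, none or still open, it means among the compounds named here.

Working notes on the series.

The series is followed in a functional assay on HeLa cells for antagonist activity at 5-hydroxytryptamine receptor 6 (Homo sapiens); a lower number here means a smaller maximal response, a higher number a larger maximal response. Compound 1, with the structure `CN1CCN(c2ccc3[nH]nc(S(=O)(=O)c4ccccc4Cl)c3c2)CC1`, gives 100% in this assay. Compound 2, with the structure `Cn1nc(S(=O)(=O)c2ccccc2)c2cc(N3CCNCC3)ccc21`, gives 100% in this assay, and compound 3, with the structure `CCn1nc(S(=O)(=O)c2cccc3ccccc23)c2cc(N3CCN(C)CC3)ccc21`, gives 100% in this assay. On these numbers compound 1 stands level with compound 2 and compound 3 at the digits shown; both gaps lie within the usual scatter, so no order can be drawn among the three. Within the data shown here, no pair of the measured compounds differs in one place only, so no single step in this assay has been measured directly.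

The next compound, compound 4, has the structure `COc1ccc(S(=O)(=O)c2n[nH]c3ccc(N4CCN(C)CC4)cc23)cc1`. It differs from compound 1 in one place: 4-methoxyphenyl in place of 2-chlorophenyl on a sulfonyl sulfur. The change sits on the sulfonyl sulfur, which carries an aromatic carbon as its other neighbour.

With all three measured compounds at the same maximal response, there is no sign in this series that varying the aryl group on the sulfonyl sulfur moves the maximal response. The step of no change at the digits printed from compound 1 to compound 4 (within the scatter) is therefore expected to be none beyond the scatter. Compound 4 is estimated at 100%, with a range from 85% to 110%.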

Compound 4, largest response reached (reported as Imax), in percent of the reference or control that the assay uses: 100%
Estimate against measurement, compound 4: no gap at the digits printed; low and high end bracket the measured number.
By their numbers in this assay, from the lowest: compounds 1, 2, 3 and 4 (each within the scatter of the next).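

Among these compounds, the reading no change at the digits printed from compound 1 to compound 4 (within the scatter) in this assay is the first direct single-change comparison, with everything outside the aryl group on the sulfonyl sulfur held fixed. Where the earlier compounds differed in more than one place at once, this pair isolates the exchange of 2-chlorophenyl, with its chlorine and 0 hydrogen-bond acceptors, for 4-methoxyphenyl, with its oxygen and 1 hydrogen-bond acceptor, and that exchange does not separate the two compounds beyond the scatter. No measurement at hand offers an explanation for this outcome.

From the compounds shown here alone, the four compounds print the same maximal response, so it remains open whether any group on the sulfonyl sulfur can move this read-out, for instance a cyclohexyl group, a longer alkyl chain, or a phenyl ring carrying an amine or a carboxylic acid. Also open, going by these compounds, is whether the exchange of 2-chlorophenyl for 4-methoxyphenyl would read the same on the core of compound 2 or compound 3, and what a single change elsewhere on the core would do.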